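The source may report more compounds than this note shows. Statements on the series, on what has been measured and on what is new or still open speak of the compounds shown alone.

Measured compounds:
compound 1, `CN1CCN(c2nc3c(S(=O)(=O)c4cccc5ccccc45)cccc3o2)CC1` – 9.7 nM in an assay on HeLa cells for displacement of a labelled ligand from 5-hydroxytryptamine receptor 6 (Homo sapiens); on this read-out lower numbers stand for stronger inhibition and higher numbers for weaker inhibition
compound 2, `CCCN1CCN(c2nc3c(S(=O)(=O)c4cccc5ccccc45)cccc3o2)CC1` – 36 nM in this assay

Of the two numbers recorded in this assay, compound 2 stands at the higher one; its nearest neighbour is compound 1, and the step of a 3.7-fold higher number from compound 1 to compound 2 (0.57 log units; beyond the scatter) lies beyond the scatter. Compound 3 `CCCCN1CCN(c2nc3c(S(=O)(=O)c4cccc5ccccc45)cccc3o2)CC1` has not yet been measured. It differs from compound 2 by methyl in place of hydrogen on a saturated chain carbon, three bonds along the chain from an amine nitrogen in a ring. Among the compounds with values here, the only measured step that speaks to this change is the chain extension from compound 1 to compound 2, where a 3.7-fold higher number from compound 1 to compound 2 (0.57 log units; beyond the scatter) was seen. Extending the chain by one further carbon is therefore expected to give at most a modest further rise in the number, or none beyond the scatter, since the one available step was itself modest. Compound 3 is accordingly estimated at 55 nM in this assay, with a range of 18 nM to 170 nM, corresponding to an expected step of a 1.5-fold higher number from compound 2 to compound 3 (0.18 log units; within the scatter).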

Compound 3, inhibition constant: 88 nM
Compound 3: middle estimate off by 1.6-fold (0.20 log units), on the low side, and the stated range covers the measured number.
By their numbers in this assay, from the lowest: compound 1; then compound 2; then compound 3.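

In this assay, methyl in place of hydrogen, three bonds along the chain from an amine nitrogen in a ring, gives a 2.4-fold higher number from compound 2 to compound 3 (0.39 log units; beyond the scatter) and so the rise in the number does not stop at propyl. Over the three compounds the whole change comes to a 9.1-fold higher number from compound 1 to compound 3 (0.96 log units; beyond the scatter) and the number rises with each added length of chain, with no compound going against this order. Nothing shown explains why the longer chains give higher numbers.

The compounds leave open whether a longer chain such as pentyl would raise the number further or level off. They also leave open how a plain hydrogen on that ring nitrogen, or a chain ending in a hydroxyl group or a phenyl ring, would compare with methyl, propyl and butyl.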